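Moving the pyridine nitrogen on an oxadiazole sulfoxide core

The compounds below may be only part of what the source reports. "The series", "measured", "known", "first", "only" and "open" are said of these compounds alone.

Measured compounds:
compound 1, `[O-][S+](Cc1ccccc1)c1nnc(-c2ccncc2)o1`: 3000 nM
compound 2, `CCCc1nnc([S+]([O-])Cc2ncc(C)c(OC)c2C)o1`: 8000 nM
compound 3, `COc1c(C)cnc(C[S+]([O-])c2nnc(-c3ccc(F)cc3)o2)c1C`: 11000 nM

The three compounds were tested in a functional assay on HUVEC cells (Homo sapiens) for inhibition, read by ELISA; a higher number here means a weaker inhibitor, a lower number a stronger inhibitor. Compound 1 stands lowest of the three numbers, so it is the strongest inhibitor among them; compound 2 sits nearer to it and compound 3 furthest, both beyond the scatter. Among the measured compounds shown here, the one step between measured compounds, a 1.4-fold higher number from compound 2 to compound 3 (0.14 log units; within the scatter), changed a different group at the same place on the core and stayed within the scatter.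

Compound 4, `[O-][S+](Cc1ccccc1)c1nnc(-c2ccccn2)o1`, differs from compound 1 only in that (pyridin-2-yl in place of pyridin-4-yl on an aromatic carbon); the two have the same atoms, joined differently. For the measured compounds named here, no measured step covers this change, so for compound 4 a step of about a 1.2-fold higher number from compound 1 to compound 4 (0.07 log units; within the scatter) is expected, essentially none beyond the scatter. Compound 4 is therefore estimated at 3500 nM, within 1500 nM to 8000 nM.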

Compound 4, half-maximal inhibitory concentration: 4000 nM
Compound 4: middle estimate off by 1.1-fold (0.06 log units), on the low side; the range from low to high includes it.
By their numbers in this assay, from the lowest: compounds 1, 4, 2 and 3 (each within the scatter of the next, the first and the last beyond it).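

Putting pyridin-2-yl in place of pyridin-4-yl gives a 1.3-fold higher number from compound 1 to compound 4 (0.12 log units; within the scatter) in this assay and so, for this pair, moving the pyridine nitrogen leaves the inhibition unchanged within the scatter. The earlier step at this place exchanged two quite different groups, whereas this one keeps the same atoms and only joins them differently. No experimental evidence here bears on this result.

From the compounds shown here alone, whether pyridin-3-yl would match these two remains open. So does whether plain phenyl, or a pyridine ring carrying an amine, would hold this level.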